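The source may hold more compounds than are shown below. What is called first, only, known or untested is meant among the compounds shown, and "the series" means these compounds.

Measured so far:
- compound 1, `O=C(CN1CCCCC1)N1N=C(c2ccc(Cl)cc2)CC1c1ccccc1O` — 7250 nM
- compound 2, `Cc1ccc(C2=NN(C(=O)CN3CCCCC3)C(c3cc(Cl)ccc3O)C2)cc1` — 14400 nM
- compound 3, `O=C(CN1CCCCC1)N1N=C(c2ccc(F)cc2)CC1c1cc(Cl)ccc1O` — 3720 nM

All three values come from an assay on isolated protein for inhibition of Amine oxidase [flavin-containing] A (Homo sapiens), read by fluorescence, with stated times of 15 min and 20 min; a higher number here means a weaker inhibitor, a lower number a stronger inhibitor. Compound 3 holds the lowest number of the three; against compound 1 the gap stays within the scatter, while compound 2 sits clearly higher, as the step of a 3.9-fold lower number from compound 2 to compound 3 (0.59 log units; beyond the scatter) shows.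

Compound 4, `O=C(CN1CCCCC1)N1N=C(c2ccc(Cl)cc2)CC1c1cc(Cl)ccc1O`, is not yet measured. It differs from compound 3 in one place: chloro in place of fluoro on an aromatic carbon.

Within the data shown here, only one measured step touches this position on the same aromatic ring, and it is not the same swap: from compound 2 to compound 3 a fluoro replaced a methyl and the number fell by a 3.9-fold lower number from compound 2 to compound 3 (0.59 log units; beyond the scatter). Among the measured compounds shown here, no measured pair shows chloro against fluoro at this carbon. For the measured compounds named here, compound 1 also carries a 4-chlorophenyl group, but it differs from compound 4 in a second place as well, so its value gives no clean single step. With a halogen exchanged for a halogen, the step from compound 3 to compound 4 in this assay is expected to stay within the scatter, leaning if anything toward a slightly higher number: a 1.2-fold higher number from compound 3 to compound 4 (0.08 log units; within the scatter). Compound 4 is therefore estimated at 4500 nM, with a range of 1800 nM to 11000 nM.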

Compound 4, half-maximal inhibitory concentration: 6010 nM
Compound 4: the middle estimate sits 1.3-fold (0.13 log units) below what was measured; low and high end bracket the measured number.
By their numbers in this assay, from the lowest: compounds 3, 4, 1 and 2 (each within the scatter of the next, the first and the last beyond it).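

Among these compounds, the step of a 1.6-fold higher number from compound 3 to compound 4 (0.21 log units; within the scatter) is the first direct comparison of the two halogens at this carbon in this assay, and it does not separate fluoro from chloro. Methyl now stands apart from both halogens at this carbon, as both a 2.4-fold lower number from compound 2 to compound 4 (0.38 log units; beyond the scatter) and a 3.9-fold lower number from compound 2 to compound 3 (0.59 log units; beyond the scatter) lie beyond the scatter, though both steps are modest and rest on compound 2 alone. With 4-chlorophenyl held constant, the step of a 1.2-fold lower number from compound 1 to compound 4 (0.08 log units; within the scatter) shows that chloro in place of hydrogen on the ring bearing the hydroxyl does not shift the number beyond the scatter in this assay.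

The compounds shown leave open whether the link between halogen and lower number extends to other groups at this carbon, such as methoxy or nitrile, or to an unsubstituted phenyl ring. Nothing available explains why methyl differs from the two halogens.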